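Spiro-fused series in HepG2: methyl step from compound 3

This account rests on a few compounds, and the source may have more. Where it says the series, first, only, none or still open, it means among the compounds named here.

Measured compounds:
compound 1 `N#CC1=C(N)Oc2c(c3nc4ccccc4nc3c3ccccc23)C12C(=O)N(Cc1cnnn1-c1ccc(F)cc1)c1ccccc12` — > 50000 nM
compound 2 `CC(=O)Nc1ccc(-n2nncc2CN2C(=O)C3(C(C#N)=C(N)Oc4c3c3nc5ccccc5nc3c3ccccc43)c3ccccc32)cc1` — > 50000 nM
compound 3 `Cc1cccc(-n2nncc2CN2C(=O)C3(C(C#N)=C(N)Oc4c(N)cc5nc6ccccc6nc5c43)c3ccccc32)c1` — > 50000 nM

In a functional assay on HepG2 cells (Homo sapiens) for antiproliferative activity, read by MTT assay, with a stated time of 48 h (on this read-out higher numbers stand for weaker inhibition and lower numbers for stronger inhibition), compound 1 reaches only the limit > 50000 nM, so no number is known for it. Compound 2 likewise sits at the limit > 50000 nM. Compound 3 also gives only the limit > 50000 nM, and nothing beyond that limit can be said of where it stands. For the measured compounds named here, the single step between measured neighbours, acetamido in place of fluoro on an aromatic carbon, is a step that the two limits leave unreadable from compound 1 to compound 2; its size is not readable because both ends sit at the limit of > 50000 nM in this assay, at which 3 of the 3 values shown sit.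

Compound 4 `Cc1ccc(C)c(-n2nncc2CN2C(=O)C3(C(C#N)=C(N)Oc4c(N)cc5nc6ccccc6nc5c43)c3ccccc32)c1` is not yet measured. It differs from compound 3 by methyl in place of hydrogen on an aromatic carbon. Going by the values given here, no measured step concerns a methyl in place of hydrogen on an aromatic carbon, and the one step that exists, a step that the two limits leave unreadable from compound 1 to compound 2, is unreadable, so nothing here points to a change beyond the scatter in this assay. With all three shown compounds at the limit, compound 4 is expected to return a limit as well, and the step that the limit leaves unreadable from compound 3 to compound 4 is an estimate, not a measured one. Compound 4 is estimated at 80000 nM, with a range from 30000 nM to 300000 nM, in the expectation that only a limit is reported.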

Compound 4, half-maximal inhibitory concentration: > 50000 nM
Compound 4 ended at the assay's limit (the forecaster's own chance of this, stated with the estimate: 85%); the middle value is on the limit's open side.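

No step can be read from compound 3 to compound 4 in this assay, because both compounds end at a limit of the assay and not at a number: the limit of > 50000 nM in this assay, at which 4 of the 4 values shown sit.

The compounds shown leave open whether any change to this series gives a readable value in this assay, and how large the step for the added methyl would be.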